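Replacing the naphthalene amide of compound 3 with bromophenyl

The source may hold more compounds than are shown below. What is called first, only, known or untested is meant among the compounds shown, and "the series" means these compounds.

The series shares one core and varies the aryl group on the amide. Compound 3 `COc1cc2c(cc1O)CN(CCCCNC(=O)c1ccc3ccccc3c1)CC2` gives 170 nM in an assay on cells for displacement of a labelled ligand from D(4) dopamine receptor (Homo sapiens) (a higher number here means a weaker inhibitor, a lower number a stronger inhibitor), the lowest of the three numbers; compound 1 `COc1cc2c(cc1O)CN(CCCCNC(=O)c1ccnc3ccccc13)CC2` gives 410 nM and compound 2 `COc1cc2c(cc1O)CN(CCCCNC(=O)c1ccncc1)CC2` gives 1400 nM. The step toward the lowest number from its nearest neighbour is a 2.4-fold lower number from compound 1 to compound 3 (0.38 log units; beyond the scatter), and from the furthest one it is an 8.2-fold lower number from compound 2 to compound 3 (0.92 log units; beyond the scatter).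

Compound 4 `COc1cc2c(cc1O)CN(CCCCNC(=O)c1ccc(Br)cc1)CC2` differs from compound 3 in one place: 4-bromophenyl in place of naphthalen-2-yl on a carbonyl carbon. Within the data shown here, no measured step matches this exactly. The closest guide is the step of a 3.4-fold higher number from compound 1 to compound 2 (0.53 log units; beyond the scatter), where one six-membered aromatic ring was lost from the aryl group and the number rose modestly. The step of an 8.2-fold lower number from compound 2 to compound 3 (0.92 log units; beyond the scatter) shows the same kind of change in the other direction, with a larger shift. Among the measured compounds shown here, the change to 4-bromophenyl again leaves only one six-membered aromatic ring, so a modest rise in the number is expected for compound 4, on the order of a 2.6-fold higher number from compound 3 to compound 4 (0.42 log units; beyond the scatter). The estimate for compound 4 in this assay is 450 nM, with a range from 150 nM to 1400 nM.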

Compound 4, inhibition constant: 350 nM
Compound 4: middle estimate off by 1.3-fold (0.11 log units), on the high side, and the stated range covers the measured number.
By their numbers in this assay, from the lowest: compound 3; then compounds 4 and 1 (each within the scatter of the next); then compound 2.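

In this assay, the step of a 2.1-fold higher number from compound 3 to compound 4 (0.31 log units; beyond the scatter) shows that 4-bromophenyl on this carbonyl carbon can stand in for naphthalen-2-yl with only a modest rise in the number, even though one six-membered aromatic ring is lost. The earlier compounds shown here left open whether a single ring here would always give a number near that of compound 2, but a 4.0-fold lower number from compound 2 to compound 4 (0.60 log units; beyond the scatter) shows that it need not, as compound 2 and compound 4 each carry one such ring on this carbonyl carbon. The step of a 1.2-fold lower number from compound 1 to compound 4 (0.07 log units; within the scatter) places the single-ring compound 4 level with the quinolin-4-yl compound 1, so ring count alone does not order these four compounds, and nothing given here explains why the aryl groups differ.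

On these data alone, what plain phenyl, 4-chlorophenyl or 4-methoxyphenyl would give on the same carbonyl carbon remains open, so the contribution of the bromine cannot be separated from that of the ring it sits on. Also open, as far as these compounds go, is whether these aryl steps would hold on a longer chain.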